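The source may hold more compounds than are shown below. What is called first, only, known or untested is meant among the compounds shown, and "the series" means these compounds.

Compound 2 `Cc1ccc(NC(=S)NC(=O)c2cn(-c3ccccc3)nc2-c2ccccc2)cc1` gives 2800 nM in a functional assay on A549 cells (Homo sapiens) for inhibition, read by CCK-8 assay, with a stated time of 48 h; a higher number here means a weaker inhibitor, a lower number a stronger inhibitor; compound 1 `Cc1ccc(NC(=S)NC(=O)c2cn(-c3ccccc3)nc2-c2ccc(C)cc2)cc1` gives 2830 nM, and the step of a 1.0-fold lower number from compound 1 to compound 2 (0.00 log units; within the scatter) on the same ring carbon is within the scatter. Compound 3 `COc1ccc(-c2nn(-c3ccccc3)cc2C(=O)NC(=S)Nc2ccc(C)cc2)cc1` carries methoxy in place of hydrogen on an aromatic carbon. Within the data shown here, the only measured step touching this position, from compound 1 to compound 2, was flat, so no movement beyond the scatter is expected in this assay for compound 3, in either direction. Compound 3 is therefore expected to give about 2800 nM, with a range of 1400 nM to 5600 nM, an expected step of no change at the digits printed from compound 2 to compound 3 (within the scatter).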

Compound 3, half-maximal inhibitory concentration: 1250 nM
Compound 3: middle estimate off by 2.2-fold (0.35 log units), on the high side, and the stated range ends above it.
By their numbers in this assay, from the lowest: compound 3; then compounds 2 and 1 (each within the scatter of the next).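

Phenyl to 4-methoxyphenyl brings a 2.2-fold lower number from compound 2 to compound 3 (0.35 log units; beyond the scatter) in this assay, and methoxy in place of methyl brings a 2.3-fold lower number from compound 1 to compound 3 (0.35 log units; beyond the scatter) on the same ring carbon. The position therefore does respond to what it carries: hydrogen and methyl stay within the scatter of each other, while methoxy gives a modest step beyond the scatter from both. Nothing on hand accounts for this step.

Open, as far as these compounds go, is whether a longer chain such as ethoxy, a hydroxyl or an amine on this carbon would extend the step or reverse it.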